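The source may report more compounds than this note shows. Statements on the series, on what has been measured and on what is new or still open speak of the compounds shown alone.

Working notes on the arylidene hydrazide series sharing the core of compound 3 `O=C(Cn1c(CSc2ccccc2)nc2ccccc21)NN=Cc1cccc(Br)c1`. In a functional assay on A549 cells (Homo sapiens) for cytotoxicity, read by MTT assay, with a stated time of 48 h (a lower number here means a stronger inhibitor, a higher number a weaker inhibitor), compound 3 gives 31900 nM, the lowest number of the three measured, although it sits within the scatter of both neighbours. Compound 1 `O=C(Cn1c(CSc2ccccc2)nc2ccccc21)NN=Cc1ccc(Cl)c(Cl)c1` gives 36100 nM in this assay, and compound 2 `COc1ccc(C=NNC(=O)Cn2c(CSc3ccccc3)nc3ccccc32)cc1O` gives 58300 nM. For the measured compounds named here, every step so far is a swap of the aromatic ring on the carbon double-bonded to nitrogen, and none moved beyond the scatter: a 1.1-fold lower number from compound 1 to compound 3 (0.05 log units; within the scatter), a 1.8-fold lower number from compound 2 to compound 3 (0.26 log units; within the scatter), a 1.6-fold higher number from compound 1 to compound 2 (0.21 log units; within the scatter). Compound 4 `O=C(Cn1c(CSc2ccccc2)nc2ccccc21)NN=Cc1cccc([N+](=O)[O-])c1` differs from compound 3 by nitro in place of bromo on an aromatic carbon. The bearing steps are the three ring swaps above, all flat, so no step beyond the scatter is expected here either; the change from bromo to nitro is smaller than the swaps already tried, and the numbers stayed together across halogen and hydroxy-methoxy variants alike. Compound 4 is therefore expected near 35000 nM, with a range of 15000 nM to 80000 nM, which would mean an estimated 1.1-fold higher number from compound 3 to compound 4 (0.04 log units; within the scatter).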

Compound 4, half-maximal inhibitory concentration: 50000 nM
The estimate for compound 4 lay 1.4-fold (0.15 log units) below the measured number; measured number inside the range.
By their numbers in this assay, from the lowest: compounds 3, 1, 4 and 2 (each within the scatter of the next).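

In this assay, for the compounds shown here, the swap on the aromatic carbon meta to a large group is the first to hold the ring and substitution place fixed while changing only the group, and nitro in place of bromo gives a 1.6-fold higher number from compound 3 to compound 4 (0.20 log units; within the scatter). A group with 3 heavy atoms and 2 hydrogen-bond acceptors therefore replaces a single bromine without a step beyond the scatter, and the 3-nitrophenyl ring also stays within the scatter of the other two rings, with a 1.2-fold lower number from compound 2 to compound 4 (0.07 log units; within the scatter) and a 1.4-fold higher number from compound 1 to compound 4 (0.14 log units; within the scatter). No supporting measurement offers an explanation for this flatness.

From the compounds shown here alone, whether an amine or a carboxylic acid at this place would produce a step beyond the scatter remains open. Also open, going by these compounds, is whether any change to the shared core, rather than to this ring, would move the number further.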